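The compounds below may be only part of what the source reports. "The series", "measured", "known", "first", "only" and "open" are said of these compounds alone.

Working notes on the series. Among the measured compounds shown here, in a functional assay on the whole organism (Tail, strain ICR) with Mus musculus as the target, in the tail flick test, with a stated time of 120 min, at a dose of 25 umol/kg by the oral route (a higher number here means a stronger effect of the compound at the dose given, a lower number a weaker effect), compound 3 `CSCC[C@H](NC(=O)CN(c1nc(Cl)nc2[nH]cnc12)C1CC1)C(=O)O` gives 5.67%, the lowest of the three numbers measured so far. In this assay compound 1 `N=C(N)NCCC[C@H](NC(=O)CN(c1nc(Cl)nc2[nH]cnc12)C1CC1)C(=O)O` gives 17%, and compound 2 `CC[C@H](C)[C@H](NC(=O)CN(c1nc(Cl)nc2[nH]cnc12)C1CC1)C(=O)O` gives 21.4%. The steps leading to compound 3 are a number 11.3 percentage points lower from compound 1 to compound 3 (beyond the scatter) and a number 15.7 percentage points lower from compound 2 to compound 3 (beyond the scatter); each changes only the group on the same chain carbon, and each is modest. Compound 4 `C[C@H](NC(=O)CN(c1nc(Cl)nc2[nH]cnc12)C1CC1)C(=O)O` has not yet been measured. Its difference from compound 3: hydrogen in place of (methylsulfanyl)methyl on a saturated chain carbon, two bonds along the chain from an amide-type nitrogen and a carbonyl carbon. For the measured compounds named here, no measured step cuts this part of the chain down to hydrogen, so the two steps above bear on it only loosely: they show that swapping the group at this position shifts the activity by modest amounts, with compound 3 at the bottom of the three. A small step is therefore expected, a number 6.3 percentage points higher from compound 3 to compound 4 (within the scatter), more likely upward than downward since compound 3 already sits lowest, though a change within the scatter is equally plausible. Compound 4 is thus estimated at 12%, with a range from 2% to 28%.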

Compound 4, a percentage reported as activity, at one dose (the size of the read-out at that dose, not a potency): 28.4%
Beside the measured number, compound 4's estimate is 16.4 percentage points below it; the whole stated range lies below it.
By their numbers in this assay, from the lowest: compound 3; then compounds 1, 2 and 4 (each within the scatter of the next, the first and the last beyond it).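

In this assay, the small methyl side chain of compound 4 does not cost activity at the dose given: loss of (methylsulfanyl)methyl gives a clear gain (a number 22.7 percentage points higher from compound 3 to compound 4 (beyond the scatter)), and the larger group of compound 1 compares the same way (a number 11.4 percentage points higher from compound 1 to compound 4 (beyond the scatter)). Against sec-butyl, the change stays inside the scatter (a number 7 percentage points higher from compound 2 to compound 4 (within the scatter)), so bulk alone does not order the series: compounds 2 and 4 cannot be separated, although compound 3 falls clearly lower than both. No evidence on hand accounts for these steps.

Going by these compounds, whether an amine, a carboxylic acid or a longer unbranched carbon chain on this carbon would match methyl remains open. A single dose and time also leave open whether these steps would hold at other doses or times.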